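Propyl for phenyl on a benzothiophene-bearing coumarin core

This account rests on a few compounds, and the source may have more. Where it says the series, first, only, none or still open, it means among the compounds named here.

Going by the values given here, compound 2 `O=c1cc(-c2ccccc2)c2c(O)cc(-c3cc4ccccc4s3)cc2o1` gives the only number in this small set: in a functional assay on MDA-MB-231 cells (Homo sapiens) for antiproliferative activity, read by MTT assay, with a stated time of 48 h (on this read-out lower numbers stand for stronger inhibition and higher numbers for weaker inhibition), compound 2 gives 10600 nM, while compound 1 `O=c1cc(-c2ccccc2)c2c(O)cc(I)cc2o1` is recorded in this assay as "not active" (no number reported). Compound 3 `CCCc1cc(=O)oc2cc(-c3cc4ccccc4s3)cc(O)c12` is the next step. Among the compounds with values here, the change from compound 2 to compound 3 is propyl in place of phenyl on an aromatic carbon, with no measured pair to show what such a swap does here. The step from compound 2 to compound 3 in this assay is therefore expected to stay within the scatter, at a 1.3-fold higher number from compound 2 to compound 3 (0.12 log units; within the scatter). For compound 3 an estimate of 14000 nM is given, expected to fall between 4000 nM and 50000 nM.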

Compound 3, half-maximal inhibitory concentration: 50000 nM
Estimate against measurement, compound 3: 3.6-fold (0.55 log units) below, and the stated range covers the measured number.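

In this assay, propyl in place of phenyl on this aromatic carbon, opposite the ring oxygen, gives a 4.7-fold higher number from compound 2 to compound 3 (0.67 log units; beyond the scatter), so the step lies beyond the scatter and this position does respond to the change. For this one pair, the ring-bearing phenyl goes with stronger inhibition than the open propyl chain. Nothing available explains the difference. The compounds shown leave open whether a longer chain such as pentyl or a shorter one such as methyl would follow propyl, and what a phenyl carrying an amine or a carboxylic acid would do here.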